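Removing the Methyl from Compound 3

The source may hold more compounds than are shown below. What is called first, only, known or untested is meant among the compounds shown, and "the series" means these compounds.

This account concerns a small set of thiosemicarbazide-type amidrazones tested in a functional assay on A-431 cells (Homo sapiens) for cytotoxicity, read by MTT assay, with a stated time of 72 h, tested at 30 uM; on this read-out higher numbers stand for more inhibition of growth at the one concentration tested and lower numbers for less inhibition of growth. Compound 1 `N/C(=N\NC(=S)N1CCN(c2ccccn2)CC1)c1ccc(F)cn1` gives 62.3% in this assay, compound 2 `N/C(=N\NC(=S)N1CCCC1)c1ccc(F)cn1` gives 83.3%, and compound 3 `Cc1cccc(/C(N)=N/NC(=S)N2CCSCC2)n1` gives 64.5%. Among these three numbers, compound 3 lies within the scatter of compound 1, so nothing separates the two, while compound 2 stands above compound 3 by a margin that is beyond the scatter.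

The step of interest leads from compound 3 to compound 4 `N/C(=N\NC(=S)N1CCSCC1)c1ccccn1`, which has not yet been measured in this assay. The change is hydrogen in place of methyl on an aromatic carbon of the six-membered aromatic ring with one nitrogen, next to the ring nitrogen and meta to a large group. Within the data shown here, no pair of measured compounds differs by this change alone, so there is no measured step to lean on.

Given the small size of the change, a step from compound 3 to compound 4 of about a number 0.5 percentage points higher from compound 3 to compound 4 (within the scatter) is expected, which is no change beyond the scatter. Compound 4 is therefore estimated to give 65% in this assay, within a range from 45% to 85%.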

Compound 4, percent growth inhibition at one concentration: 81.3%
The estimate for compound 4 lay 16.3 percentage points below the measured number; the range from low to high includes it.
By their numbers in this assay, from the lowest: compounds 1 and 3 (each within the scatter of the next); then compounds 4 and 2 (each within the scatter of the next).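

In this assay, hydrogen in place of methyl on an aromatic carbon gives a number 16.8 percentage points higher from compound 3 to compound 4 (beyond the scatter). Among these compounds, this shows that the position, on the six-membered aromatic ring with one nitrogen and next to the ring nitrogen, is not indifferent to this small change: the loss of a single carbon moves the read-out by more than the scatter, something the earlier compounds could not show because no pair among them differed by this change alone. The finding rests on this one pair, and nothing available bears on why the methyl has this effect.

The compounds shown leave open whether the step is particular to methyl or would also appear with another group in the same place, such as ethyl, methoxy or chlorine in place of the hydrogen of compound 4. Also open, going by these compounds, is whether the same exchange would give a step of similar size on the rest of the scaffold as it stands in compound 1 or compound 2, where the groups on the thiocarbonyl differ.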